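This account rests on a few compounds, and the source may have more. Where it says the series, first, only, none or still open, it means among the compounds named here.

Measured so far in a functional assay on CCRF-CEM cells (Homo sapiens) for antiproliferative activity, with a stated time of 72 h; a lower number here means a stronger inhibitor, a higher number a weaker inhibitor:
- compound 1 `OC[C@H]1O[C@@H](n2cnc3c(NCc4ccc(F)cc4)ncnc32)[C@H](O)[C@@H]1O`: 1250 nM
- compound 2 `OC[C@H]1O[C@@H](n2cnc3c(NCc4cccc(Br)c4)ncnc32)[C@H](O)[C@@H]1O`: 5000 nM
- compound 3 `Cc1cccc(CNc2ncnc3c2ncn3[C@@H]2O[C@H](CO)[C@@H](O)[C@H]2O)c1`: 19100 nM

Compound 2 gives 5000 nM, the second highest of the three numbers. Compound 3 lies above this value and compound 1 below it, with both gaps beyond the scatter.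

The next case is compound 4 `COc1cccc(CNc2ncnc3c2ncn3[C@@H]2O[C@H](CO)[C@@H](O)[C@H]2O)c1`, with the change (methoxy in place of bromo on an aromatic carbon). This places methoxy in place of bromo on an aromatic carbon, meta to a large group. For the measured compounds named here, no methoxy compound has been measured in this set, so the expectation rests on neighbouring changes.

The closest measured change is a 3.8-fold higher number from compound 2 to compound 3 (0.58 log units; beyond the scatter), which puts methyl in place of bromo on the same aromatic carbon. That modest step gives the main guide to direction. The steps of a 4.0-fold higher number from compound 1 to compound 2 (0.60 log units; beyond the scatter) and a 15-fold higher number from compound 1 to compound 3 (1.18 log units; beyond the scatter) also lead to higher numbers, one modest and one large, but both start from 4-fluorophenyl and bear on this change only indirectly.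

A modest move to a higher number is therefore expected, smaller than the move seen with methyl. The expected step is a 2.2-fold higher number from compound 2 to compound 4 (0.34 log units; beyond the scatter). For compound 4 the estimate is 11000 nM, with an expected range of 3500 nM to 30000 nM.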

Compound 4, half-maximal inhibitory concentration: 7600 nM
Compound 4: middle estimate off by 1.4-fold (0.16 log units), on the high side; the range from low to high includes it.
By their numbers in this assay, from the lowest: compound 1; then compounds 2 and 4 (each within the scatter of the next); then compound 3.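

In this assay, methoxy and bromo on this aromatic carbon cannot be told apart (a 1.5-fold higher number from compound 2 to compound 4 (0.18 log units; within the scatter)), while methoxy and methyl at the same place do separate (a 2.5-fold lower number from compound 3 to compound 4 (0.40 log units; beyond the scatter)), so the high number of compound 3 is not shared by the other two groups tested here. The new 3-methoxyphenyl compound also stays clearly short of the 4-fluorophenyl compound (a 6.1-fold higher number from compound 1 to compound 4 (0.78 log units; beyond the scatter)), which keeps the lowest number of the four, with its steps to all three others beyond the scatter. No measurement at hand offers an explanation for why methyl separates from methoxy and bromo at this place.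

The steps from compound 1 alter both the group and its place on the phenyl ring, and the compounds shown do not separate these two changes. From the compounds shown here alone, it also remains open how an amine, a carboxylic acid or a longer alkoxy chain on the same aromatic carbon would compare with compound 2 and compound 4 in this assay.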